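A few compounds are considered here, and "the series" means these few. Any claim that something is new, unique, unknown or untested is made for them only; others in the source may bear on it.

Measured so far:
compound 1 `Nc1ccccc1NC(=O)c1ccc(CSc2ccc(C(F)(F)F)cn2)cc1`, 25.8% 
compound 2 `COc1ccc(SCc2ccc(C(=O)Nc3ccccc3N)cc2)cc1`, 90.1% 
compound 3 `Nc1ccccc1NC(=O)/C=C/c1ccc(CSc2cccc(F)c2)cc1`, 3.22% 

In a functional assay on HCT-116 cells (Homo sapiens) for inhibition, read by CCK-8 assay, with a stated time of 72 h, tested at 8 uM (on this read-out lower numbers stand for less inhibition of growth and higher numbers for more inhibition of growth at the one concentration tested), compound 2 gives 90.1%, the highest of the three numbers; its steps to compound 1 and to compound 3 both lie beyond the scatter, so compound 2 is the strongest of the measured set. Compound 4 `Nc1ccccc1NC(=O)c1ccc(CSc2ccc(Cl)cc2)cc1` is not yet measured. It differs from compound 2 in one place: chloro in place of methoxy on an aromatic carbon. Among the measured compounds shown here, no pair measured so far differs only at that position, so the size of this step is unsupported by any direct comparison. Given that the two weaker compounds carry a halogen rather than methoxy, a drop beyond the scatter is expected, of about a number 30.1 percentage points lower from compound 2 to compound 4 (beyond the scatter). Compound 4 is therefore estimated at 60%, with a range from 25% to 88%.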

Compound 4, percent growth inhibition at one concentration: 76.6%
Beside the measured number, compound 4's estimate is 16.6 percentage points below it; low and high end bracket the measured number.
By their numbers in this assay, from the lowest: compound 3; then compound 1; then compound 4; then compound 2.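

In this assay, among the compounds shown here, the change from 4-methoxyphenyl to 4-chlorophenyl gives a number 13.5 percentage points lower from compound 2 to compound 4 (beyond the scatter) and is the first direct comparison at this position. The aromatic carbon para to a large group therefore accepts chloro in place of methoxy at a real but limited cost, with compound 4 still giving strong growth inhibition at the one concentration tested. Nothing measured accounts for the step.

From the compounds shown here alone, whether an amine, a carboxylic acid or a longer chain such as ethoxy at this position would hold the inhibition remains open. Going by these compounds, whether the step carries over to other cores also remains open.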